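From 2-Chlorophenyl to 2-Nitrophenyl in a Cytotoxic Series

A few compounds are considered here, and "the series" means these few. Any claim that something is new, unique, unknown or untested is made for them only; others in the source may bear on it.

In a functional assay on MCF7 cells (Homo sapiens) for cytotoxicity, read by MTT assay, with a stated time of 96 h (a lower number here means a stronger inhibitor, a higher number a weaker inhibitor), compound 1 `COc1cc(C(=O)c2cn(-c3ccccc3)cc2-c2ccc(N)cc2)cc(OC)c1OC` gives 9 nM, compound 2 `COc1cc(C(=O)c2cn(-c3ccccc3C)cc2-c2ccccc2)cc(OC)c1OC` gives 2200 nM, and compound 3 `COc1cc(C(=O)c2cn(-c3ccccc3Cl)cc2-c2ccccc2)cc(OC)c1OC` gives 1800 nM. Compound 3 therefore sits level with compound 2 within the usual scatter, and both numbers lie far above that of compound 1, which also differs from them in more than one place.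

The next structure, compound 4 `COc1cc(C(=O)c2cn(-c3ccccc3[N+](=O)[O-])cc2-c2ccccc2)cc(OC)c1OC`, carries nitro in place of chloro on an aromatic carbon, ortho to a large group (nitro in place of chloro on an aromatic carbon). Within the data shown here, one measured step bears on this change: chloro in place of methyl on an aromatic carbon gave a 1.2-fold lower number from compound 2 to compound 3 (0.09 log units; within the scatter). Among the measured compounds shown here, that is a single, small step, and no nitro compound has been measured yet, so the evidence is thin. In this assay, the expected step is a 1.1-fold higher number from compound 3 to compound 4 (0.05 log units; within the scatter), which means no change beyond the scatter and no firm direction. Compound 4 is estimated at 2000 nM, with an expected range from 700 nM to 5500 nM.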

Compound 4, half-maximal inhibitory concentration: 5000 nM
For compound 4 the middle estimate is 2.5-fold (0.40 log units) below the measured one; low and high end bracket the measured number.
By their numbers in this assay, from the lowest: compound 1; then compounds 3 and 2 (each within the scatter of the next); then compound 4.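

Methyl and chloro on this aromatic carbon, ortho to a large group, could not be told apart, but nitro can be separated from both in this assay: the swap from chloro gives a 2.8-fold higher number from compound 3 to compound 4 (0.44 log units; beyond the scatter), and the swap from methyl gives a 2.3-fold higher number from compound 2 to compound 4 (0.36 log units; beyond the scatter). The position is therefore not indifferent to the group it carries, although the size of both steps is modest next to the much larger gap that separates these compounds from compound 1. No measured property of these groups is available to explain the nitro steps.

Going by these compounds, it remains open how an amine or a methoxy group on this aromatic carbon would compare with these three groups. Compound 1 carries no group at this carbon but also differs elsewhere, so the share of its gap that belongs to this position cannot be read.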